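Swapping the thiophene for a dichlorophenyl on a chalcone

This account rests on a few compounds, and the source may have more. Where it says the series, first, only, none or still open, it means among the compounds named here.

Measured so far:
compound 1, `O=C(/C=C/c1ccccc1)c1cccc(NC(=O)c2cc(-c3ccncc3)n[nH]2)c1`, 71500 nM
compound 2, `O=C(/C=C/c1ccc(Cl)cc1)c1cccc(NC(=O)c2cc(-c3ccncc3)n[nH]2)c1`, 78900 nM
compound 3, `O=C(/C=C/c1cccs1)c1cccc(NC(=O)c2cc(-c3ccncc3)n[nH]2)c1`, 70000 nM

All three compounds share one core and differ only in the aromatic ring at the far end of the chain. Within the data shown here, in a functional assay, read by spectrophotometry, tested at 100 uM (on this read-out lower numbers stand for stronger inhibition and higher numbers for weaker inhibition), compound 3 sits at the low end of the three numbers, but the gaps to its neighbours, a 1.0-fold lower number from compound 1 to compound 3 (0.01 log units; within the scatter) and a 1.1-fold lower number from compound 2 to compound 3 (0.05 log units; within the scatter), are both within the scatter, so no compound can be set apart from the others.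

Compound 4, `O=C(/C=C/c1ccc(Cl)cc1Cl)c1cccc(NC(=O)c2cc(-c3ccncc3)n[nH]2)c1`, has not yet been measured. It differs from compound 3 as follows: 2,4-dichlorophenyl in place of thiophen-2-yl on a double-bonded chain carbon bound to a double-bonded chain carbon.

Among the measured compounds shown here, three steps bear on this change. Putting chloro in place of hydrogen on an aromatic carbon gave a 1.1-fold higher number from compound 1 to compound 2 (0.04 log units; within the scatter). Exchanging phenyl or 4-chlorophenyl for thiophen-2-yl gave a 1.0-fold lower number from compound 1 to compound 3 (0.01 log units; within the scatter) and a 1.1-fold lower number from compound 2 to compound 3 (0.05 log units; within the scatter). Every change at this ring so far stayed within the scatter, so for compound 4 a step of about a 1.1-fold higher number from compound 3 to compound 4 (0.03 log units; within the scatter) is expected, not beyond the scatter in either direction. In this assay compound 4 is therefore estimated at 75000 nM, with a range from 35000 nM to 160000 nM.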

Compound 4, half-maximal inhibitory concentration: 80900 nM
Estimate against measurement, compound 4: 1.1-fold (0.03 log units) below; the range from low to high includes it.
By their numbers in this assay, from the lowest: compounds 3, 1, 2 and 4 (each within the scatter of the next).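

In this assay, among these compounds, a second chloro on the ring gives a 1.0-fold higher number from compound 2 to compound 4 (0.01 log units; within the scatter), a kind of change that the earlier compounds, with at most one chloro on this ring, could not show. The wider exchanges at the same place, on a double-bonded chain carbon, also stay within the scatter, with a 1.2-fold higher number from compound 3 to compound 4 (0.06 log units; within the scatter) and a 1.1-fold higher number from compound 1 to compound 4 (0.05 log units; within the scatter). Across these four compounds, then, the 2,4-dichlorophenyl ring cannot be told apart from phenyl, 4-chlorophenyl or thiophen-2-yl, and no outside measurement helps to explain why these numbers stay so close.

From the compounds shown here alone, every group tried here is an uncharged aromatic ring, so it remains open whether an amine or a carboxylic acid on this ring would move the number beyond the scatter. Going by these compounds, a saturated cyclohexyl ring in its place is equally open, as is any change to the shared core.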